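A few compounds are considered here, and "the series" means these few. Any claim that something is new, unique, unknown or untested is made for them only; others in the source may bear on it.

Of the compounds shown here, two on a shared core have been measured so far. In a functional assay on T-24 cells (Homo sapiens) for antiproliferative activity, read by MTT assay, with a stated time of 72 h (on this read-out higher numbers stand for weaker inhibition and lower numbers for stronger inhibition), compound 1 (`CC(C)CNC(=N)NC(=N)Nc1ccc(F)c(F)c1`) gives 42900 nM and compound 2 (`CC(C)NC(=N)NC(=N)Nc1ccc(F)c(F)c1`) gives 45000 nM and these two numbers lie within the scatter of each other. Compound 3 (`CCN(CC)C(=N)NC(=N)Nc1ccc(F)c(F)c1`) differs from compound 2 in one place, with diethylamino in place of isopropylamino on a carbon with a double bond to nitrogen. Within the data shown here, the only measured step (a 1.0-fold higher number from compound 1 to compound 2 (0.02 log units; within the scatter)) also changes the group on an amine nitrogen, and it stays within the scatter. Among the measured compounds shown here, no measured compound carries diethylamino, so this single step is a thin guide. In this assay the expected step (no change at the digits printed from compound 2 to compound 3 (within the scatter)) is therefore none beyond the scatter, with no direction favoured. The estimate for compound 3 is 45000 nM (expected range 18000 nM to 100000 nM).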

Compound 3, half-maximal inhibitory concentration: 44800 nM
For compound 3 the middle estimate is 1.0-fold (0.00 log units) above the measured one, and the stated range covers the measured number.
By their numbers in this assay, from the lowest: compounds 1, 3 and 2 (each within the scatter of the next).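

In this assay, the step of a 1.0-fold lower number from compound 2 to compound 3 (0.00 log units; within the scatter) shows that this position can lose the hydrogen-bond donor counted on isopropylamino, and gain the heavy atom that diethylamino adds, with the number staying within the scatter. The step of a 1.0-fold higher number from compound 1 to compound 3 (0.02 log units; within the scatter), with diethylamino in place of isobutylamino, also stays within the scatter, so the three groups on this carbon cannot be told apart in this read-out. No evidence is available that explains this result.

From the compounds shown here alone, whether a piperidine ring, a longer chain or a carboxylic acid at this place would give a number beyond the scatter remains open. Also open, going by these compounds, is whether the same result would hold for these groups on a core that does not carry the two fluorines of the shared core.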